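This account rests on a few compounds, and the source may have more. Where it says the series, first, only, none or still open, it means among the compounds named here.

In a functional assay on MDA-MB-435S cells (Homo sapiens) for cytotoxicity, read by MTT assay, with a stated time of 72 h (on this read-out higher numbers stand for weaker inhibition and lower numbers for stronger inhibition), three compounds have been examined so far. Compound 1 `Cc1nnc(Sc2c(C)oc3ccccc3c2=O)o1` gives only a limit, > 50000 nM, rather than a number. Compound 3 `O=c1cc(CSc2nc3ccccc3s2)oc2ccc(Cl)cc12` likewise stops at a limit, > 25000 nM. Among the measured compounds shown here, compound 2 `Cc1cc(C)n2nc(SCc3nnc(SCc4coc5ccccc5c4=O)n3N)nc2n1` is the one compound that yields a number, 3000 nM, and it stands alone as the single measured value. The two remaining results are limits; one sits at the limit of > 25000 nM in this assay, at which 1 of the 3 values shown sits, and the other at the limit of > 50000 nM in this assay, at which 1 of the 3 values shown sits.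

Compound 4 `Cc1cc(C)n2nc(SCc3nnc(SCc4coc5ccccc5c4=O)n3-c3ccccc3)nc2n1` is drawn from compound 2 by a single change: phenyl in place of amino on an aromatic nitrogen, on an aromatic nitrogen of a five-membered aromatic ring with three nitrogens, two ring bonds from the ring nitrogen. For the measured compounds named here, no pair of measured compounds shows a step of this kind, so there is nothing to calibrate against; compound 1 and compound 3 differ from compound 2 in many places at once and say nothing about this one exchange.

The step from compound 2 to compound 4 in this assay is expected to be small, in either direction, and most likely not beyond the scatter of repeated runs, a 1.2-fold higher number from compound 2 to compound 4 (0.07 log units; within the scatter). Compound 4 is therefore estimated at 3500 nM, within a range from 1000 nM to 15000 nM.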

Compound 4, half-maximal inhibitory concentration: 2900 nM
Estimate against measurement, compound 4: 1.2-fold (0.08 log units) above, and the stated range covers the measured number.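

In this assay, among the compounds shown here, the exchange comes to a 1.0-fold lower number from compound 2 to compound 4 (0.01 log units; within the scatter), the first step at this position and the first comparison between two compounds that differ in one place. On an aromatic nitrogen of a five-membered aromatic ring with three nitrogens, a phenyl of 6 heavy atoms, with 0 hydrogen-bond donors and 0 hydrogen-bond acceptors, thus takes the place of an amino of 1 heavy atom, with 1 hydrogen-bond donor and 1 hydrogen-bond acceptor, and the read-out does not tell compound 2 and compound 4 apart. The information available offers no measurement that explains why these two compounds cannot be told apart.

As far as these compounds go, whether a methyl, a benzyl or a pyridine ring on the same nitrogen would also stay within the scatter of compound 2 remains open, so this single step cannot show how far the position tolerates other groups. Also open is which parts of the structure shared by compound 2 and compound 4 matter for the read-out, as no step among the compounds shown changes any part other than this nitrogen substituent.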